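The compounds below may be only part of what the source reports. "The series", "measured", "known", "first", "only" and "open" are said of these compounds alone.

Values in an ADME assay on L1210/0 cells (Mus musculus) for cytotoxicity, with a stated time of 48 h; on this read-out higher numbers stand for weaker inhibition and lower numbers for stronger inhibition:
- Compound 1 `N#CSc1cn([C@H]2C[C@H](O)[C@@H](CO)O2)c(=O)[nH]c1=O`: 78900 nM
- Compound 2 `O=C(CI)NCc1cn([C@H]2C[C@H](O)[C@@H](CO)O2)c(=O)[nH]c1=O`: 107000 nM
- Compound 3 `C[S+]([O-])c1cn([C@H]2C[C@H](O)[C@@H](CO)O2)c(=O)[nH]c1=O`: > 200000 nM

The entry for compound 3 is a limit of the assay and not a number, as the limit of > 200000 nM in this assay, at which 1 of the 3 values shown sits, records. Compound 4 `CCCC/C=C\c1cn([C@H]2C[C@H](O)[C@@H](CO)O2)c(=O)[nH]c1=O` differs from it by a group of 6 heavy atoms (6 carbon; no ring) in place of a group of 3 heavy atoms (1 carbon, 1 oxygen, 1 sulfur; no ring), on an aromatic carbon, bringing in hex-1-en-1-yl. Three measured steps change the group at this place: a 1.4-fold higher number from compound 1 to compound 2 (0.13 log units; within the scatter), an at least 2.5-fold higher number from compound 1 to compound 3 (0.40 log units; beyond the scatter) and an at least 1.8-fold higher number from compound 2 to compound 3 (0.27 log units; that floor lies within the scatter). All are small, so only a small step towards a lower number in this assay is expected, and compound 4 may also stay at the limit. The expected step is an at least 2.0-fold lower number from compound 3 to compound 4 (0.30 log units; that floor lies within the scatter). Compound 4 is estimated at 100000 nM. That estimate is expected to lie between 35000 nM and 200000 nM.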

Compound 4, half-maximal inhibitory concentration: > 200000 nM
Compound 4 gave a limit, no number; the forecaster's own chance of this, stated with the estimate: 35%; at least 2.0-fold (0.30 log units) between middle value and limit.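

In this assay compound 4 gives a limit, not a number, so a group made of carbon alone at this aromatic carbon ends at the same entry as compound 3: the limit of > 200000 nM in this assay, at which 2 of the 4 values shown sit. Replacing the earlier groups with hex-1-en-1-yl gives an at least 2.5-fold higher number from compound 1 to compound 4 (0.40 log units; beyond the scatter) and an at least 1.8-fold higher number from compound 2 to compound 4 (0.27 log units; that floor lies within the scatter). The step between compound 3 and compound 4 cannot be read, since both entries are limits.

Going by these compounds, how far compound 3 and compound 4 lie beyond that limit stays open. So does whether a shorter chain or an amine here would return a number.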